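Aryl swap on the thiophene series: thiophen-2-yl for difluorophenyl

This account rests on a few compounds, and the source may have more. Where it says the series, first, only, none or still open, it means among the compounds named here.

Measured so far in an assay on CHO cells for displacement of a labelled ligand from adenosine receptor A1 (Homo sapiens), read by scintillation counting, tested at 10 uM; on this read-out lower numbers stand for less inhibition and higher numbers for more inhibition at the one concentration tested (going by the name of the read-out):
compound 1 `CC(C)(C)Cc1c(-c2ccc(F)cc2F)sc(N)c1C(=O)c1ccc(Cl)cc1` — 1%
compound 2 `CC(C)(C)Cc1c(-c2ccc(OC(F)(F)F)cc2)sc(N)c1C(=O)c1ccc(Cl)cc1` — 1%

Compound 1 stands level with compound 2 in this assay; the two values differ by nothing at the digits shown, which lies within the scatter. Both sit at the bottom of the read-out.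

Compound 3 `CC(C)(C)Cc1c(-c2cccs2)sc(N)c1C(=O)c1ccc(Cl)cc1` is not yet measured. The change from compound 1 is thiophen-2-yl in place of 2,4-difluorophenyl on an aromatic carbon.

Within the data shown here, with only two flat values to build on, no step beyond the scatter is expected in this assay, in either direction. Compound 3 is therefore expected to come in near 3%, within 0% to 15%, and the step of a number 2 percentage points higher from compound 1 to compound 3 (within the scatter) is expected to be small.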

Compound 3, a percentage reported as inhibition, at one concentration (the size of the read-out at that concentration, not a potency): 1%
Compound 3: the middle estimate sits 2 percentage points above what was measured, within the range that was stated.
By their numbers in this assay, from the lowest: compounds 1, 2 and 3 (each within the scatter of the next).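

In this assay, thiophen-2-yl in place of 2,4-difluorophenyl gives no change at the digits printed from compound 1 to compound 3 (within the scatter) and so the flat read-out now covers a five-membered aromatic ring with 1 sulfur as well as the substituted phenyl rings of compound 1 and compound 2. At this position, the ring swap alone leaves the value at the bottom of the read-out. Nothing measured here bears on why the read-out stays flat.

Still open, on these data alone, is whether an amine or a carboxylic acid on the aryl group at this position would move the value. As far as these compounds go, a longer chain in place of the neopentyl group also remains open.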